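The source may hold more compounds than are shown below. What is called first, only, known or untested is meant among the compounds shown, and "the series" means these compounds.

Compound 1 `CC(=O)c1ccc(NC(=O)Nc2cc(C)nc3ccccc23)cc1` stands at 22000 nM in an ADME assay on BJ cells (Homo sapiens) for cytotoxicity, with a stated time of 72 h (a higher number here means that more compound is needed for the effect, a lower number that less compound is needed), the lowest of the two numbers shown, though compound 2 `COc1ccc(NC(=O)Nc2cc(C)nc3ccccc23)cc1Cl` at 23000 nM sits within the scatter of it, so no order between the two can be claimed. Compound 3 `Cc1cc(NC(=O)Nc2cc(Cl)cc(Cl)c2)c2ccccc2n1` gives only a limit of the assay in this assay, > 25000 nM. Among the compounds with values here, that limit, (the limit of > 25000 nM in this assay, at which 1 of the 3 values shown sits), is the one value shown that is not a number. Compound 4 `Cc1cc(NC(=O)Nc2ccc(Cl)cc2)c2ccccc2n1` differs from compound 1 by chloro in place of acetyl on an aromatic carbon. Within the data shown here, no step between measured compounds is available for this change, so the expected step in this assay, a 1.1-fold higher number from compound 1 to compound 4 (0.06 log units; within the scatter), is small and may well stay within the scatter, with a lean toward a higher number. Compound 4 is therefore estimated at 25000 nM, between 12000 nM and 50000 nM.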

Compound 4, half-maximal effective concentration: > 25000 nM
Compound 4 was reported as a limit; the forecaster's own chance of this, stated with the estimate: 45%; the middle value lies on the limit itself.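

Chloro in place of acetyl on this aromatic carbon gives the first step read at this position, an at least 1.1-fold higher number from compound 1 to compound 4 (0.05 log units; that floor lies within the scatter), and as a floor it sets no upper bound on the change. In this assay compound 4 gives > 25000 nM, which is a limit of the assay and not a number. The limit now accounts for as many values as the numbers do: the limit of > 25000 nM in this assay, at which 2 of the 4 values shown sit.

The compounds shown leave open how large the step from acetyl to chloro really is. They also leave open whether an amine or a carboxylic acid on this aromatic carbon would give a number rather than a limit.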